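This account rests on a few compounds, and the source may have more. Where it says the series, first, only, none or still open, it means among the compounds named here.

Measured compounds, inhibition of the mitochondrial enzyme:

- compound 1, `CC(C)=CCn1c(CN2CCN(C(=O)C3CC3)CC2)nc2ccccc21`: 1480 nM
- compound 2, `CCC(=O)N1CCN(Cc2nc3ccccc3n2Cc2cccc(C)c2)CC1`: 3230 nM
- compound 3, `Cc1cccc(Cn2c(CN3CCN(C(=O)C(C)C)CC3)nc3ccccc32)c1`: 2270 nM

In an assay on isolated protein for inhibition of aldehyde dehydrogenase, mitochondrial (Homo sapiens), read by spectrophotometry (on this read-out lower numbers stand for stronger inhibition and higher numbers for weaker inhibition), compound 1 has the lowest of the three numbers. Against compound 3 the gap is within the scatter, so the two cannot be ordered; against compound 2 the gap lies beyond the scatter, compound 1 giving the lower number. Among the compounds with values here, the only step measured within one position is a 1.4-fold lower number from compound 2 to compound 3 (0.15 log units; within the scatter), which alters the acyl group on the piperazine and leaves the substituent on the aromatic nitrogen untouched.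

Compound 4, `O=C(C1CC1)N1CCN(Cc2nc3ccccc3n2Cc2cccc(Cl)c2)CC1`, is to be measured in this assay. It differs from compound 1 by 3-chlorophenyl in place of 2-methylprop-1-en-1-yl on a saturated chain carbon bound to an aromatic nitrogen. Within the data shown here, no measured step changes this position, so the one step on record does not bear on it directly. Among the measured compounds shown here, what the series does show is that compounds 2 and 3, carrying a benzyl group on the aromatic nitrogen in place of the 3-methylbut-2-en-1-yl chain of compound 1, land near compound 1 in this assay, with the only clear separation being the one between compound 1 and compound 2. The benzyl series and the alkenyl chain therefore seem to sit in the same region of this assay, and a 3-chlorobenzyl group is expected to behave alike.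

The expectation for compound 4 is therefore a 1.2-fold higher number from compound 1 to compound 4 (0.09 log units; within the scatter), a step not expected to exceed the scatter, with an estimated value of 1800 nM (range 700 nM to 4500 nM).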

Compound 4, half-maximal inhibitory concentration: 2310 nM
Beside the measured number, compound 4's estimate is 1.3-fold (0.11 log units) below it; the range from low to high includes it.
By their numbers in this assay, from the lowest: compounds 1, 3, 4 and 2 (each within the scatter of the next, the first and the last beyond it).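

In this assay, the position on a saturated chain carbon bound to an aromatic nitrogen now has its first direct reading: a 1.6-fold higher number from compound 1 to compound 4 (0.19 log units; within the scatter) for the change from 3-methylbut-2-en-1-yl to 3-chlorobenzyl, with the rest of compound 1 kept. Before this pair, the benzyl groups could be set against the alkenyl chain only through compounds that also differed in the acyl group on the piperazine, whereas here the exchange of an open chain carrying one double bond for a six-membered aromatic ring bearing chlorine stands alone and stays within the scatter, so neither group can be ranked over the other. Nothing at hand accounts for the two groups reading alike, and this single pair sets no trend for the position.

Compounds 3 and 4 differ in two places, so the chlorine and the methyl on the benzyl group remain uncompared with one acyl group held fixed. Also open, as far as these compounds go, is how an unsubstituted benzyl, a benzyl carrying an amine or a carboxylic acid, or a longer chain would read at this position.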